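Shortening the ether substituent in a bis-chromone series

The compounds below may be only part of what the source reports. "The series", "measured", "known", "first", "only" and "open" are said of these compounds alone.

Within the data shown here, compound 2 `O=c1c(Cc2coc3cccc(OCC4CCCCC4)c3c2=O)coc2ccccc12` gives the highest of the two numbers so far in a functional assay on ACHN cells (Homo sapiens) for antiproliferative activity, read by XTT assay (a higher number here means a weaker inhibitor, a lower number a stronger inhibitor), namely 4230 nM; its nearest neighbour, compound 1 `COc1cccc2occ(Cc3coc4ccccc4c3=O)c(=O)c12`, gives 340 nM. Among the measured compounds shown here, the one measured step, a 12-fold higher number from compound 1 to compound 2 (1.09 log units; beyond the scatter), shows that the cyclohexyl group on the saturated chain carbon bound to the aromatic ring oxygen is accompanied by a large weakening. Compound 3 `CC(C)CCOc1cccc2occ(Cc3coc4ccccc4c3=O)c(=O)c12` has not yet been measured. It differs from compound 2 as follows: isobutyl in place of cyclohexyl on a saturated chain carbon bound to an oxygen on an aromatic ring. For the measured compounds named here, no step between compound 2 and compound 3 has been observed, but the isobutyl group still keeps a chain of four carbons at the position where compound 1 carries only hydrogen. Compound 3 is therefore expected to sit between compound 1 and compound 2 in this assay, a step of a 2.4-fold lower number from compound 2 to compound 3 (0.37 log units; beyond the scatter), with an estimate of 1800 nM and a range from 600 nM to 5000 nM.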

Compound 3, half-maximal inhibitory concentration: 3960 nM
Compound 3: middle estimate off by 2.2-fold (0.34 log units), on the low side; low and high end bracket the measured number.
By their numbers in this assay, from the lowest: compound 1; then compounds 3 and 2 (each within the scatter of the next).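

In this assay, the step of a 1.1-fold lower number from compound 2 to compound 3 (0.03 log units; within the scatter) lies within the scatter, so exchanging cyclohexyl for isobutyl on a saturated chain carbon bound to an oxygen on an aromatic ring has no discernible effect, even though the ring is gone and the group has 4 rather than 6 heavy atoms. The step of a 12-fold higher number from compound 1 to compound 3 (1.07 log units; beyond the scatter) is large and beyond the scatter, as is a 12-fold higher number from compound 1 to compound 2 (1.09 log units; beyond the scatter), so among these compounds the large weakening relative to compound 1 does not depend on having a ring in the substituent. No measurement is available that would explain this result.

The compounds shown leave open how a group smaller than isobutyl, such as an ethyl group, would compare at this place. They also leave open whether a chain ending in an amine or a carboxylic acid would fall nearer to compound 1 or to compound 2 and compound 3.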